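6-Phenylhexyl carbamate on the undecynyl ester core

This account rests on a few compounds, and the source may have more. Where it says the series, first, only, none or still open, it means among the compounds named here.

Measured so far:
compound 1 `NC(=O)c1ccn(-c2cccc(OC(=O)NCCCCCCc3ccccc3)c2)c1`, 0.6 nM
compound 2 `C#CCCCCCCCCCOC(=O)c1ccn(-c2cccc(OC(=O)NC3CCCCC3)c2)c1`, > 10000 nM

Compound 1 is a carbamate bearing 6-phenylhexyl on the amide-type nitrogen; in an assay (brain) for inhibition of Fatty-acid amide hydrolase 1 (Mus musculus), with stated times of 20 min and 15 min (a lower number here means a stronger inhibitor, a higher number a weaker inhibitor), compound 1 gives 0.6 nM. Compound 2 `C#CCCCCCCCCCOC(=O)c1ccn(-c2cccc(OC(=O)NC3CCCCC3)c2)c1` carries cyclohexyl on that nitrogen and an undecynyl ester on the shared core; for compound 2 the entry > 10000 nM is a limit of the assay and not a number, as noted by the limit of > 10000 nM in this assay, at which 1 of the 2 values shown sits. Compound 2 therefore stands at the weak end of what is shown here.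

Compound 3 `C#CCCCCCCCCCOC(=O)c1ccn(-c2cccc(OC(=O)NCCCCCCc3ccccc3)c2)c1` keeps the ester core of compound 2 and differs from it in one place: 6-phenylhexyl in place of cyclohexyl on an amide-type nitrogen. Among the compounds with values here, no measured step covers this change. Within the data shown here, still, the 6-phenylhexyl carbamate is the one present in compound 1, whose 0.6 nM is strong, so the step is expected to be a large gain in potency, an at least 200-fold lower number from compound 2 to compound 3 (2.30 log units; beyond the scatter). Compound 3 is estimated at 50 nM, within 3 nM to 2000 nM.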

Compound 3, half-maximal inhibitory concentration: > 200 nM
Compound 3: only a limit was reported; the forecaster's own chance of this, stated with the estimate: 15%; at least 4.0-fold (0.60 log units) between middle value and limit.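

In this assay compound 3 gives > 200 nM, which is a limit of the assay and not a number. With the 6-phenylhexyl carbamate held fixed, (undec-10-yn-1-yl)oxy in place of amino on a carbonyl carbon gives an at least 330-fold higher number from compound 1 to compound 3 (2.52 log units; beyond the scatter). The group on that carbonyl carbon therefore matters strongly in this series, and 6-phenylhexyl on the amide-type nitrogen does not by itself secure the potency of compound 1.

On these data alone, the step for 6-phenylhexyl in place of cyclohexyl cannot be read, as both of its ends are limits, so any effect of that change on the undecynyl ester core remains unknown. Also open, as far as these compounds go, is how a carboxylic acid, a methyl ester or a shorter alkynyl ester on that carbonyl carbon would stand against amino and (undec-10-yn-1-yl)oxy.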